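Replacing pyrrolidin-1-yl with methoxy on the shared core

A few compounds are considered here, and "the series" means these few. Any claim that something is new, unique, unknown or untested is made for them only; others in the source may bear on it.

Compounds measured in an ADME assay on microsomes from liver (Rattus norvegicus) for metabolic stability; a higher number here means faster removal of the compound, a lower number slower removal:
Compound 1 `CNc1nc(NC2(C#N)CCCCC2)nc(-n2ccnc2)n1`: 52 mL/min/kg
Compound 2 `CNc1nc(NC2(C#N)CCCCC2)nc(N2CCCC2)n1`: > 276 mL/min/kg (a limit of the assay, not a number)

Going by the values given here, compound 2 has no exact clearance in this assay, only a limit, and it stands at the top of the compounds measured so far: the limit of > 276 mL/min/kg in this assay, at which 1 of the 2 values shown sits. The next compound, compound 3 `CNc1nc(NC2(C#N)CCCCC2)nc(OC)n1`, carries methoxy in place of pyrrolidin-1-yl on an aromatic carbon, opposite the ring nitrogen: methoxy in place of pyrrolidin-1-yl on an aromatic carbon.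

Among the compounds with values here, only one measured step bears on this place in the molecule. It puts pyrrolidin-1-yl in place of 1H-imidazol-1-yl and is beyond the scatter: an at least 5.3-fold higher number from compound 1 to compound 2 (0.72 log units; beyond the scatter). Going by these compounds, that step is itself open-ended, so its true size is unknown, and it involves a different incoming group. Still, compound 1 at 52 mL/min/kg shows that the core can reach a much lower number without pyrrolidin-1-yl. A move towards slower removal is therefore expected, probably beyond the scatter. The expected change is an at least 2.5-fold lower number from compound 2 to compound 3 (0.39 log units; beyond the scatter). For compound 3 the estimated clearance is 110 mL/min/kg, with an expected range from 40 mL/min/kg to 260 mL/min/kg.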

Compound 3, clearance: 196 mL/min/kg
Beside the measured number, compound 3's estimate is 1.8-fold (0.25 log units) below it; low and high end bracket the measured number.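

In this assay, the move from pyrrolidin-1-yl to methoxy on this aromatic carbon, between two ring nitrogen atoms, can be read only as a floor (an at least 1.4-fold lower number from compound 2 to compound 3 (0.14 log units; that floor lies within the scatter)), so these two groups are not yet shown to differ by more than the scatter. Methoxy, however, does not reach the number seen with 1H-imidazol-1-yl (a 3.8-fold higher number from compound 1 to compound 3 (0.58 log units; beyond the scatter)), which shows that removing pyrrolidin-1-yl alone is not enough and that, among the three groups shown, 1H-imidazol-1-yl gives the lowest number, with its steps to both others beyond the scatter. The value of compound 2 is a limit of the assay and not a number, so the true size of the step to methoxy stays unknown: the limit of > 276 mL/min/kg in this assay, at which 1 of the 3 values shown sits.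

The three groups do not sort by ring or size, since the two rings, 1H-imidazol-1-yl and pyrrolidin-1-yl, are far apart in this read-out while methoxy, which has no ring, falls clear of compound 1 alone. Going by these compounds, how a morpholin-4-yl ring, a simple primary amine or a longer chain such as ethoxy would behave at this place remains open.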